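Replacing the triazole arm with a hydroxypiperidine chain

The source may hold more compounds than are shown below. What is called first, only, known or untested is meant among the compounds shown, and "the series" means these compounds.

Compound 3 `O=C1c2c[n+]([O-])c3ccccc3c2C(=O)c2c1c1ccccc1n2Cc1cn(CC(O)CO)nn1` carries a 2,3-dihydroxypropyl group on the 1H-1,2,3-triazol-4-yl ring that sits on the aromatic nitrogen of the shared core. In a functional assay on SH-SY5Y cells (Homo sapiens) for cytotoxicity, read by MTT assay, with a stated time of 72 h (a lower number here means a stronger inhibitor, a higher number a weaker inhibitor), compound 3 reaches only a limit, > 1000 nM. Compound 1 `O=C1c2c[n+]([O-])c3ccccc3c2C(=O)c2c1c1ccccc1n2Cc1cn([C@H]2C[C@H](O)[C@@H](CO)O2)nn1` gives 620 nM in this assay. Compound 2 `CC1(C)O[C@@H](CO)[C@H](Cn2cc(Cn3c4c(c5ccccc53)C(=O)c3c[n+]([O-])c5ccccc5c3C4=O)nn2)O1` likewise reaches only a limit in this assay, > 1000 nM. The measured steps read an at least 1.6-fold higher number from compound 1 to compound 3 (0.20 log units; that floor lies within the scatter) and an at least 1.6-fold higher number from compound 1 to compound 2 (0.20 log units; that floor lies within the scatter), while a step that the two limits leave unreadable from compound 2 to compound 3; compound 3 thus stands at the weaker edge of what the numbers show, without a number of its own, and the limit of > 1000 nM in this assay, at which 2 of the 3 values shown sit, keeps the spread readable only as a floor.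

Compound 4 `O=C1c2c[n+]([O-])c3ccccc3c2C(=O)c2c1c1ccccc1n2CCCN1CCC(O)CC1` is the next target. (2-(4-hydroxypiperidin-1-yl)ethyl in place of 1-(2,3-dihydroxypropyl)-1H-1,2,3-triazol-4-yl on a saturated chain carbon bound to an aromatic nitrogen). For the measured compounds named here, none of the measured steps touches the 1H-1,2,3-triazol-4-yl ring itself; each of them varies only the group attached to it, so no measured step gives the size or direction of this change. With compound 3 known only as a limit, the expectation for compound 4 is a step of an at least 1.1-fold lower number from compound 3 to compound 4 (0.04 log units; that floor lies within the scatter), with neither direction favoured beyond the scatter. Compound 4 is estimated at 900 nM, within 300 nM to 3000 nM, with a fair chance that this assay again reports only a limit.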

Compound 4, half-maximal inhibitory concentration: 130 nM
Compound 4: middle estimate off by 6.9-fold (0.84 log units), on the high side; the measured number lies below the stated range.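

In this assay, for the compounds shown here, the earlier steps varied only the group carried on the 1H-1,2,3-triazol-4-yl ring, whereas here that ring itself gives way to 2-(4-hydroxypiperidin-1-yl)ethyl, and this exchange gives an at least 7.6-fold lower number from compound 3 to compound 4 (0.88 log units; beyond the scatter) on a saturated chain carbon bound to an aromatic nitrogen. This position therefore accepts an arm without the triazole ring, and compound 4 gives 130 nM as a full number rather than a limit. The size of the step remains a floor, since compound 3 has no number of its own: the limit of > 1000 nM in this assay, at which 2 of the 4 values shown sit.

The step from compound 2 to compound 3 cannot be read, and the exchange alters the ring, its hetero atoms and the chain together, so the compounds shown do not separate the contributions of the piperidine ring, its hydroxyl group and the 3-(4-hydroxypiperidin-1-yl)propyl chain length. Going by these compounds, whether a plain piperidine, a morpholine ring or a longer chain at this place would keep the lower number remains open.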